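Chloro in Place of Hydrogen: Expecting Compound 4

This account rests on a few compounds, and the source may have more. Where it says the series, first, only, none or still open, it means among the compounds named here.

Compound 1 `O=C(Nc1nc2ccc(Cl)cc2s1)c1cn(-c2ccccc2)nc1-c1ccccc1` gives 7670 nM in a functional assay on A549 cells (Homo sapiens) for cytotoxicity, read by MTT assay, with a stated time of 72 h; on this read-out lower numbers stand for stronger inhibition and higher numbers for weaker inhibition. For compound 2 `COc1ccc2nc(NC(=O)c3cn(-c4ccccc4)nc3-c3ccccc3)sc2c1` the result is a limit of the assay, > 50000 nM. Compound 3 `Cc1ccc2nc(NC(=O)c3cn(-c4ccccc4)nc3-c3ccccc3)sc2c1` gives 26500 nM.

Compound 3 has the higher of the two numbers; the nearest is compound 1, with a 3.5-fold higher number from compound 1 to compound 3 (0.54 log units; beyond the scatter). Compound 4 `Cc1ccc2nc(NC(=O)c3cn(-c4ccccc4)nc3-c3ccc(Cl)cc3)sc2c1` differs from compound 3 by chloro in place of hydrogen on an aromatic carbon, so that phenyl becomes 4-chlorophenyl. The measured steps, an at least 6.5-fold higher number from compound 1 to compound 2 (0.81 log units; beyond the scatter) and a 3.5-fold higher number from compound 1 to compound 3 (0.54 log units; beyond the scatter), both exchange the chloro on the other aromatic ring, and an at least 1.8-fold lower number from compound 2 to compound 3 (0.27 log units; that floor lies within the scatter) stays within the scatter; none of them tests a chloro at this place. The expected step, a 1.3-fold lower number from compound 3 to compound 4 (0.12 log units; within the scatter), is therefore kept small. Compound 4 is estimated at 20000 nM, with a range from 7000 nM to 50000 nM.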

Compound 4, half-maximal inhibitory concentration: 18600 nM
Compound 4: the middle estimate sits 1.1-fold (0.03 log units) above what was measured, and the stated range covers the measured number.
By their numbers in this assay, from the lowest: compound 1; then compounds 4 and 3 (each within the scatter of the next). At a limit, above all of these: compound 2.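

Chloro in place of hydrogen, turning phenyl into 4-chlorophenyl, gives a 1.4-fold lower number from compound 3 to compound 4 (0.15 log units; within the scatter), so in this assay this position takes a chloro without a change that can be told from the scatter. The earlier compounds shown here varied only the other aromatic ring, where both steps from compound 1 went beyond the scatter. No measurement at hand bears on this result.

On these data alone, it stays open whether 4-chlorophenyl would give the same outcome alongside the chloro of compound 1. As far as these compounds go, it also stays open what an amine or a carboxylic acid at this position would do.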